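A few compounds are considered here, and "the series" means these few. Any claim that something is new, unique, unknown or untested is made for them only; others in the source may bear on it.

Three measured compounds share the same core, an aromatic ring carrying a ketone that leads into an unsaturated acid. Compound 1 `Cc1ccc(C)c(C(=O)/C=C/C(=O)O)c1`, compound 2 `CCc1ccc(C(=O)/C=C/C(=O)O)cc1` and compound 3 `O=C(O)/C=C/C(=O)c1cc(C2CCCCC2)ccc1C1CCCCC1` differ only in what sits on that ring. In a functional assay on K562 cells (Homo sapiens) for inhibition, read by MTT assay, with a stated time of 72 h (on this read-out higher numbers stand for weaker inhibition and lower numbers for stronger inhibition), compound 1 gives 5900 nM, compound 2 gives 5530 nM and compound 3 gives 3320 nM. Compound 2 sits between the other two, and all three numbers lie within the usual scatter of one another. The next compound, compound 4 `O=C(O)/C=C/C(=O)c1ccc(Br)cc1`, has not been measured. It differs from compound 2 in one place: bromo in place of ethyl on an aromatic carbon. Among the measured compounds shown here, no pair of measured compounds differing in a single place is available, so no step beyond the scatter is expected. Compound 4 is estimated at 5000 nM, between 2500 nM and 10000 nM, which would mean an expected step of a 1.1-fold lower number from compound 2 to compound 4 (0.04 log units; within the scatter).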

Compound 4, half-maximal inhibitory concentration: 11200 nM
Compound 4: the middle estimate sits 2.2-fold (0.35 log units) below what was measured; measured number above the stated range.
By their numbers in this assay, from the lowest: compounds 3, 2, 1 and 4 (each within the scatter of the next, the first and the last beyond it).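

Among the compounds shown here, this is the first single-place change that can be read. Bromo in place of ethyl gives a 2.0-fold higher number from compound 2 to compound 4 (0.31 log units; beyond the scatter) in this assay and so weaker inhibition. The aromatic carbon para to a group of 7 heavy atoms therefore responds to what it carries, though the step is modest. Nothing at hand explains this step. As far as these compounds go, it remains open how other groups on this same carbon would read, such as a methoxy group, an amine or a longer chain. With only ethyl and bromo to compare, no trend across substituents at this position can be drawn.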